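This account rests on a few compounds, and the source may have more. Where it says the series, first, only, none or still open, it means among the compounds named here.

Of the compounds shown here, three built on a shared core have been measured so far. In a functional assay on A549 cells (Homo sapiens) for antiproliferative activity, read by sulforhodamine B assay, with a stated time of 3 days (on this read-out lower numbers stand for stronger inhibition of growth and higher numbers for weaker inhibition of growth), compound 1 `COc1ccc(N2CCN(C)CC2)cc1Nc1ncc(F)c(Nc2ccc(F)cc2)n1` gives 1130 nM. Compound 2 `O=C(Nc1ccc(C(F)(F)F)cc1)c1cccc(Nc2ncc(F)c(Nc3ccc(F)cc3)n2)c1` gives > 10000 nM, which is a limit of the assay and not a true number. Compound 3 `O=C(Nc1cccc(Nc2ncc(F)c(Nc3ccc(F)cc3)n2)c1)c1cccc([N+](=O)[O-])c1` gives 7250 nM. Of the two results that are true numbers, this is the higher one, so compound 3 inhibits growth more weakly than compound 1, and the gap between them lies beyond the scatter of repeated measurements.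

The next molecule is compound 4 `COCC(=O)Nc1cccc(Nc2ncc(F)c(Nc3ccc(F)cc3)n2)c1`, which has methoxymethyl in place of 3-nitrophenyl on a carbonyl carbon. The six-membered aromatic ring of that group is lost, and the entering group has no ring. Among the compounds with values here, no measured pair of compounds shows this change, so the expectation is rough. Compound 1 carries no such amide and gives 1130 nM, which suggests that values lower than that of compound 3 are possible on this core. A small move toward stronger inhibition is therefore expected, with the estimated step of a 1.8-fold lower number from compound 3 to compound 4 (0.26 log units; within the scatter). For compound 4 the expected value in this assay is 4000 nM, with an estimated range from 1200 nM to 12000 nM.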

Compound 4, concentration for 50% growth inhibition: 2050 nM
Beside the measured number, compound 4's estimate is 2.0-fold (0.29 log units) above it; the measured number falls inside the stated range.
By their numbers in this assay, from the lowest: compounds 1 and 4 (each within the scatter of the next); then compound 3. At a limit, above all of these: compound 2.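

Within the data shown here, on the carbonyl carbon of the amide, methoxymethyl in place of 3-nitrophenyl gives a 3.5-fold lower number from compound 3 to compound 4 (0.55 log units; beyond the scatter); this is the first step between two measured compounds that differ in one place. It shows that in this assay the six-membered aromatic ring of 3-nitrophenyl is not needed on this carbonyl carbon for growth inhibition, since compound 4, whose group has no ring, inhibits growth more strongly than compound 3. Compound 2 gives a result that is a limit and not a true number, so it cannot show how far an aromatic amide can weaken growth inhibition on this core: the limit of > 10000 nM in this assay, at which 1 of the 4 values shown sits.

This single pair removes the ring, the nitro group and several heavy atoms all at once, so it cannot tell which of these differences goes with the stronger inhibition. As far as these compounds go, how the value would respond on the same carbonyl carbon to an unsubstituted phenyl, which would keep the ring without the nitro group, or to a plain methyl, a longer ether chain or a chain ending in a dimethylamine, stays open.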